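The source may report more compounds than this note shows. Statements on the series, on what has been measured and on what is new or still open speak of the compounds shown alone.

Measured compounds:
- compound 1, `COc1cccc(OC)c1OCCNCCOc1ccccc1OCc1ccccc1Cl`: 5400 nM
- compound 2, `COc1cccc(OC)c1OCCNCCOc1ccccc1OCc1ccc(Cl)cc1`: 2400 nM
- compound 3, `COc1cccc(OC)c1OCCNCCOc1ccccc1OCc1ccc(C)cc1`: 7800 nM

All three were tested in a functional assay on PC-3 cells (Homo sapiens) for cytotoxicity, read by sulforhodamine B assay; on this read-out higher numbers stand for weaker inhibition of growth and lower numbers for stronger inhibition of growth. Compound 3 gives the highest number of the three; its gap to compound 1 lies within the scatter, while a 3.3-fold higher number from compound 2 to compound 3 (0.51 log units; beyond the scatter) lies beyond it. Compound 4, `COc1ccccc1COc1ccccc1OCCNCCOc1c(OC)cccc1OC`, is not yet measured. It differs from compound 3 by 2-methoxyphenyl in place of 4-methylphenyl on a saturated chain carbon bound to an oxygen on an aromatic ring. The step that bears most directly on it is a 1.4-fold higher number from compound 1 to compound 3 (0.16 log units; within the scatter), where a 2-chlorophenyl in the same place changed nothing beyond the scatter. Also relevant is a 2.3-fold lower number from compound 1 to compound 2 (0.35 log units; beyond the scatter), a modest shift. A 2-methoxyphenyl itself has not been seen here, so the expectation rests on these neighbours. Compound 4 is therefore expected to show a 1.3-fold lower number from compound 3 to compound 4 (0.11 log units; within the scatter), nothing clearly beyond the scatter, with an estimate of 6000 nM ranging from 2500 nM to 15000 nM.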

Compound 4, concentration for 50% growth inhibition: 8900 nM
The estimate for compound 4 lay 1.5-fold (0.17 log units) below the measured number; the range from low to high includes it.
By their numbers in this assay, from the lowest: compound 2; then compounds 1, 3 and 4 (each within the scatter of the next).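

At this place on the saturated chain carbon, 2-methoxyphenyl in place of 4-methylphenyl gives a 1.1-fold higher number from compound 3 to compound 4 (0.06 log units; within the scatter) and methoxy in place of chloro gives a 1.6-fold higher number from compound 1 to compound 4 (0.22 log units; within the scatter) so neither swap clearly moves growth inhibition. Compound 2 now stands apart from a third neighbour, with a 3.7-fold higher number from compound 2 to compound 4 (0.57 log units; beyond the scatter) and its 4-chlorophenyl gives the lowest number of the four. Nothing measured here explains this difference.

Going by these compounds, whether a 4-methoxyphenyl would match the 4-chlorophenyl remains open. So does the outcome with an unsubstituted phenyl or a 4-fluorophenyl at this place.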